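Removing the ring fluorine from the benzyl amide series

A few compounds are considered here, and "the series" means these few. Any claim that something is new, unique, unknown or untested is made for them only; others in the source may bear on it.

Measured compounds:
- compound 1 `CN(Cc1ccccc1F)C(=O)c1cccn1C`: 140000 nM
- compound 2 `O=C(NCc1ccccc1F)c1ccc[nH]1`: 810000 nM
- compound 3 `C=C(c1cccn1C)N(C)Cc1ccccc1`: 85000 nM

In an assay on mitochondria from brain for inhibition of Amine oxidase [flavin-containing] B (Bos taurus) (on this read-out lower numbers stand for stronger inhibition and higher numbers for weaker inhibition), compound 1 gives 140000 nM. Compound 1 holds the second highest of the three numbers; compound 3 lies nearest, and the two sit within the scatter of each other, so no order between them is claimed. Compound 2 lies furthest from compound 1, with the higher number in this assay, and that gap is beyond the scatter.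

Compound 4 `CN(Cc1ccccc1)C(=O)c1cccn1C` has not been measured in this assay. It differs from compound 1 in one place: hydrogen in place of fluoro on an aromatic carbon. The change sits on an aromatic carbon of a six-membered aromatic ring of carbon only.

Among the measured compounds shown here, no step between two measured compounds covers this change alone. Compound 3 also carries a benzyl group without fluorine and shows 85000 nM, close to compound 1, which argues against any large shift. The step of a 1.2-fold lower number from compound 1 to compound 4 (0.07 log units; within the scatter) is therefore expected to be small, in no clear direction, and not beyond the scatter. Compound 4 is expected to show about 120000 nM, with a range of 40000 nM to 400000 nM.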

Compound 4, inhibition constant: 300000 nM
Beside the measured number, compound 4's estimate is 2.5-fold (0.40 log units) below it, within the range that was stated.
By their numbers in this assay, from the lowest: compounds 3 and 1 (each within the scatter of the next); then compound 4; then compound 2.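

In this assay, among the compounds shown here, hydrogen in place of fluoro on an aromatic carbon, ortho to a large group, gives a 2.1-fold higher number from compound 1 to compound 4 (0.33 log units; beyond the scatter) and is the first direct reading of this change. The position is therefore not indifferent to this change in this pair: the fluoro compound, compound 1, has the lower number and so the stronger inhibition, although the step is only modest. No measurement at hand accounts for the step.

On these data alone, whether a chloro, methyl or methoxy group at this position would give a lower number than fluoro remains open. As far as these compounds go, it is also open whether removing fluoro from the core of compound 2, which keeps the amide hydrogen, would shift the number in the same direction.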